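A chlorothiophene in place of phenyl on the shared core

The source may report more compounds than this note shows. Statements on the series, on what has been measured and on what is new or still open speak of the compounds shown alone.

Compound 1 `CCCc1cc(NNC(=O)Nc2cc(Cl)nc(Cl)c2)nc2c1c(C)nn2C`: 2360 nM
Compound 2 `COc1ccc(-c2cc(NNC(=O)Nc3cc(Cl)nc(Cl)c3)nc3c2c(C)nn3C)cc1`: 1020 nM
Compound 3 `Cc1nn(C)c2nc(NNC(=O)Nc3cc(Cl)nc(Cl)c3)cc(-c3ccccc3)c12`: 5320 nM

Of the compounds shown here, three on a shared core have been measured in an assay on isolated protein for binding affinity to sphingosine 1-phosphate receptor 2 (Homo sapiens), read by surface plasmon resonance; on this read-out higher numbers stand for weaker binding and lower numbers for tighter binding. Compound 3 stands highest of the three numbers; the nearest is compound 1, the furthest compound 2. The step of a 2.3-fold higher number from compound 1 to compound 3 (0.35 log units; beyond the scatter) and the step of a 5.2-fold higher number from compound 2 to compound 3 (0.72 log units; beyond the scatter) both lie beyond the scatter, so compound 3 is the weakest binder of the three.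

Compound 4 `Cc1nn(C)c2nc(NNC(=O)Nc3cc(Cl)nc(Cl)c3)cc(-c3ccc(Cl)s3)c12` has not yet been measured. It differs from compound 3 by 5-chlorothiophen-2-yl in place of phenyl on an aromatic carbon. Among the compounds with values here, no measured step swaps one aromatic ring for another, so the bearing is indirect. The steps of a 2.3-fold lower number from compound 1 to compound 2 (0.36 log units; beyond the scatter) and a 2.3-fold higher number from compound 1 to compound 3 (0.35 log units; beyond the scatter) show that the group at this position moves the number modestly in either direction, and a 5.2-fold higher number from compound 2 to compound 3 (0.72 log units; beyond the scatter) shows that a single substituent on the aryl ring gave the largest shift seen. On this basis a modest downward step is expected, a 1.8-fold lower number from compound 3 to compound 4 (0.25 log units; within the scatter), with wide uncertainty. Compound 4 is therefore estimated at 3000 nM, within a range of 800 nM to 12000 nM.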

Compound 4, dissociation constant: 1980 nM
The estimate for compound 4 lay 1.5-fold (0.18 log units) above the measured number, within the range that was stated.
By their numbers in this assay, from the lowest: compounds 2, 4 and 1 (each within the scatter of the next, the first and the last beyond it); then compound 3.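

In this assay, within the data shown here, the 5-chlorothiophen-2-yl group in place of phenyl gave a step beyond the scatter (a 2.7-fold lower number from compound 3 to compound 4 (0.43 log units; beyond the scatter)), the first measured exchange of one aromatic ring for another at this position, opposite the ring nitrogen. The new group cannot be ranked against the other two substituents, as both comparisons lie within the scatter (a 1.9-fold higher number from compound 2 to compound 4 (0.29 log units; within the scatter); a 1.2-fold lower number from compound 1 to compound 4 (0.08 log units; within the scatter)), so a five-membered aromatic ring with a chlorine reads alongside both 4-methoxyphenyl and propyl here. Nothing available explains this step.

The compounds shown leave open whether the step belongs to the five-membered ring or to its chlorine, which a plain thiophen-2-yl or a 4-chlorophenyl at this position would separate. Going by these compounds, how an amine or a carboxylic acid would read at this position also remains open.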